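Amino substitution on the pendant phenyl of the shared core

The source may hold more compounds than are shown below. What is called first, only, known or untested is meant among the compounds shown, and "the series" means these compounds.

Compound 2 `COc1cc2c(cc1OC)C(c1ccccc1)=NNC(=O)C2` carries an unsubstituted phenyl on the shared core. In a functional assay on the whole organism with Mus musculus as the target (on this read-out lower numbers stand for an effect already at smaller amounts and higher numbers for an effect only at larger amounts of compound), compound 2 gives 33.9 umol/kg, the lowest of the two numbers at hand. Compound 1 `COc1cc2c(cc1OC)C(c1ccc(Br)cc1)=NNC(=O)C2` gives 110 umol/kg in this assay, and the step of a 3.2-fold lower number from compound 1 to compound 2 (0.51 log units; beyond the scatter) is beyond the scatter. Compound 3 `COc1cc2c(cc1OC)C(c1cccc([N+](=O)[O-])c1)=NNC(=O)C2` reaches only a limit in this assay, > 120 umol/kg. The step of an at least 3.5-fold higher number from compound 2 to compound 3 (0.54 log units; beyond the scatter) is likewise beyond the scatter. Compound 4 `COc1cc2c(cc1OC)C(c1ccc(N)cc1)=NNC(=O)C2` differs from compound 2 by amino in place of hydrogen on an aromatic carbon. Both substituted phenyls measured so far stand higher than compound 2, so a modest rise in this assay is expected for the amino group as well. Compound 4 is estimated at 70 umol/kg, within 30 umol/kg to 130 umol/kg. The expected step is a 2.1-fold higher number from compound 2 to compound 4 (0.31 log units; beyond the scatter).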

Compound 4, dose for half-maximal effect: 15 umol/kg
Compound 4: middle estimate off by 4.7-fold (0.67 log units), on the high side, outside the stated range (below it).
By their numbers in this assay, from the lowest: compound 4; then compound 2; then compound 1. At a limit, above all of these: compound 3.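

In this assay, substitution on the phenyl does not always raise the number: amino para to a large group gives a 2.3-fold lower number from compound 2 to compound 4 (0.35 log units; beyond the scatter), whereas compound 1 and compound 3 both stand higher than compound 2. The entering group decides the direction here, as the swap of bromo for amino shows: a 7.3-fold lower number from compound 1 to compound 4 (0.87 log units; beyond the scatter). Going by these compounds, whether methoxy, hydroxy or dimethylamino at this place would follow amino or bromo remains open. Compound 3 stands at a limit, so its distance from the other compounds remains unfixed: the limit of > 120 umol/kg in this assay, at which 1 of the 4 values shown sits.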